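Notes on a tetrahydroisoquinoline series: amide chain variation

A few compounds are considered here, and "the series" means these few. Any claim that something is new, unique, unknown or untested is made for them only; others in the source may bear on it.

Measured so far in a functional assay on the whole organism for inhibition of sodium-dependent dopamine transporter (Mus musculus); a higher number here means that more compound is needed for the effect, a lower number that less compound is needed:
- compound 1 `Cc1ccc(C2CN(C)Cc3c(N)cccc32)cc1` gives about 22 mg/kg
- compound 2 `CCCCNC(=O)Nc1cccc2c1CN(C)CC2c1ccc(C)cc1` gives > 100 mg/kg
- compound 3 `CCNCC(=O)Nc1cccc2c1CN(C)CC2c1ccccc1` gives about 60 mg/kg

The value of compound 2 is a limit of this assay, not a number; it sits at the limit of > 100 mg/kg in this assay, at which 1 of the 3 values shown sits. Compound 3 holds the highest of the two numbers, with compound 1 the nearest, a lower one. For the measured compounds named here, the only measured step, an at least 4.5-fold higher number from compound 1 to compound 2 (0.65 log units; beyond the scatter), shows that a larger group on the ring nitrogen raised the number at least modestly.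

Compound 4 `CN1Cc2c(NC(=O)CN3CCCCC3)cccc2C(c2ccccc2)C1` differs from compound 3 by piperidin-1-yl in place of ethylamino on a saturated chain carbon bound to a carbonyl carbon. Going by the values given here, no measured step covers this kind of exchange: the step from compound 1 to compound 2 concerns a different part of the molecule, and compounds 1 and 3 differ in two places, so their values alone cannot be read as a step. The replacement keeps a basic amine on the chain while removing its donor hydrogen; with no bearing evidence, the expected step of no change at the digits printed from compound 3 to compound 4 (within the scatter) is none beyond the scatter, though a wider range is kept. Compound 4 is therefore estimated at 60 mg/kg, between 25 mg/kg and 150 mg/kg.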

Compound 4, dose for half-maximal effect: about 60 mg/kg
Compound 4: the middle estimate sits on the measured number at the digits printed; the range from low to high includes it.
By their numbers in this assay, from the lowest: compound 1; then compounds 3 and 4 (each within the scatter of the next). At a limit, above all of these: compound 2.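

In this assay, for the compounds shown here, piperidin-1-yl in place of ethylamino on a saturated chain carbon bound to a carbonyl carbon gives no change at the digits printed from compound 3 to compound 4 (within the scatter), the first reading at this place, as the only earlier step concerned a different part of the molecule. Going from 3 to 6 heavy atoms, adding a six-membered non-aromatic ring and going from 1 hydrogen-bond donor to 0 therefore moves the number by nothing beyond the scatter in this pair. Nothing measured in the series bears on why this exchange behaves as it does.

Open, as far as these compounds go, is whether a carboxylic acid, a morpholin-4-yl group or a longer chain at this place would read the same way as ethylamino and piperidin-1-yl. Also open, from the compounds shown here alone, is whether the same exchange reads alike on the core of compound 1.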